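The compounds below may be only part of what the source reports. "The series", "measured", "known", "first", "only" and "open" are said of these compounds alone.

Series notes on the shared core. In an assay on isolated protein for inhibition of histone acetyltransferase p300 (Homo sapiens), read by fluorescence, with a stated time of 5 min, in the presence of a further agent that is not named here (on this read-out lower numbers stand for stronger inhibition and higher numbers for weaker inhibition), compound 1 `NC(=O)c1ccc(O)c2ccccc12` gives "not determined" (no result reported), so no result is reported for it. Compound 2 `Cc1ccc(S(=O)(=O)Nc2ccc(O)c3ccccc23)cc1` is the only member with a number: in this assay compound 2 gives 2600 nM, so on the numbers shown it stands alone, with no second measured compound against which a step could be set. Compound 3 `CS(=O)(=O)Nc1ccc(O)c2ccccc12` differs from compound 2 in a single place: methyl in place of 4-methylphenyl on a sulfonyl sulfur. Among the compounds with values here, no step between measured compounds is available to calibrate a change of this kind. With 4-methylphenyl leaving and methyl entering on the sulfonyl sulfur, the expectation is a move toward weaker inhibition that goes beyond the usual scatter, though not a very large one; the expected step is a 3.5-fold higher number from compound 2 to compound 3 (0.54 log units; beyond the scatter). Compound 3 is accordingly estimated at 9000 nM, with a likely range from 3000 nM to 30000 nM.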

Compound 3, half-maximal inhibitory concentration: 3000 nM
Beside the measured number, compound 3's estimate is 3.0-fold (0.48 log units) above it; the measured number falls inside the stated range.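

In this assay, methyl in place of 4-methylphenyl on a sulfonyl sulfur gives a 1.2-fold higher number from compound 2 to compound 3 (0.06 log units; within the scatter), so compound 2 and compound 3 cannot be told apart on this read-out. This place therefore tolerates the loss of the whole six-membered aromatic ring of carbon only, and on these two compounds the 4-methylphenyl group is not needed for the inhibition seen. Nothing measured here accounts for this flat step.

Steps involving compound 1 cannot be read, as it carries no number. Also open, from the compounds shown here alone, is whether this tolerance holds for other groups on the sulfonyl sulfur, such as a longer chain like n-butyl, a chain ending in an amine or a carboxylic acid, or a phenyl ring bearing a different substituent.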